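Loss of the amino group on the shared core

A few compounds are considered here, and "the series" means these few. Any claim that something is new, unique, unknown or untested is made for them only; others in the source may bear on it.

Measured compounds:
compound 1, `CC[C@H]1CN(c2nc(N)c(C(=O)NCCS(C)(=O)=O)nc2Cl)CCN1C1CCN(Cc2ccc(Cl)cc2)CC1`, 6.4 nM
compound 2, `CC[C@H]1CN(c2nc(N)c(C(=O)NCCO)nc2Cl)CCN1C1CCN(C(=O)c2ccc(Cl)nc2N)CC1`, 3.4 nM

Among the measured compounds shown here, both compounds have been measured in an in vitro assay on BaF3 cells for displacement of a labelled ligand from C-X-C chemokine receptor type 3 (Homo sapiens); a lower number here means a stronger inhibitor, a higher number a weaker inhibitor. Compound 2 gives the lower of the two numbers; compound 1 lies within the scatter of it, so the two are not ordered. For the measured compounds named here, no step between them is defined, as they differ in more than one place.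

Compound 3, `CC[C@H]1CN(c2ncc(C(=O)NCCO)nc2Cl)CCN1C1CCN(C(=O)c2ccc(Cl)nc2N)CC1`, has not yet been measured. It differs from compound 2 in one place: hydrogen in place of amino on an aromatic carbon of the shared core. Going by the values given here, no pair of measured compounds shows what this change does, so the expectation rests only on the value of compound 2 in this assay and on the size of the change itself, which takes away one heavy atom and the donor and acceptor that came with it.

The step from compound 2 to compound 3 is expected to be a loss, an 8.8-fold higher number from compound 2 to compound 3 (0.95 log units; beyond the scatter), estimated as going beyond the scatter but of uncertain size. Compound 3 is therefore expected to give about 30 nM in this assay, between 8 nM and 120 nM.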

Compound 3, half-maximal inhibitory concentration: 2.9 nM
For compound 3 the middle estimate is 10-fold (1.01 log units) above the measured one; the whole stated range lies above it.
By their numbers in this assay, from the lowest: compounds 3, 2 and 1 (each within the scatter of the next, the first and the last beyond it).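

In this assay, among the compounds shown here, hydrogen in place of amino on an aromatic carbon of the shared core gives a 1.2-fold lower number from compound 2 to compound 3 (0.07 log units; within the scatter) and this is the first single change that can be read. On this carbon, next to the ring nitrogen and para to a chloro group, the amino group goes with its one heavy atom, its hydrogen-bond donor and its acceptor, and yet compound 2 at 3.4 nM and compound 3 at 2.9 nM cannot be ordered, so with the (2-hydroxyethyl)carbamoyl group and the rest of compound 2 in place the amino group makes no readable difference to this number. For the compounds shown here, nothing measured so far bears on why this is so.

A methyl group, a fluoro group or a methoxy group on the same carbon would show whether this position reads alike for substituents other than hydrogen and amino, which compound 2 and compound 3 cannot tell. Equally open, from the compounds shown here alone, is whether the same exchange would read alike on compound 1, which differs from compound 2 in more than one place.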